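The compounds below may be only part of what the source reports. "The series", "measured", "known", "first", "only" and "open" are said of these compounds alone.

For the measured compounds named here, in a functional assay on K562 cells (Homo sapiens) for antiproliferative activity, read by MTT assay, with a stated time of 72 h (on this read-out higher numbers stand for weaker inhibition and lower numbers for stronger inhibition), compound 2 `CC(C)=CC[C@H]1C[C@]23C[C@@H](CC=C(C)C)C(C)(C)[C@H]4CCC(C)(C)O[C@]42OC(=O)C(C(=O)c2ccc(O)c(O)c2)=C3OC1(C)C` gives 7690 nM, the only true number among the measured compounds. Compound 1 `COc1ccc(C(=O)Oc2ccc(C(=O)C3=C4OC(C)(C)[C@@H](CC=C(C)C)C[C@@]45C[C@@H](CC=C(C)C)C(C)(C)[C@H]4CCC(C)(C)O[C@]45OC3=O)cc2OC(=O)c2ccc(OC)cc2)cc1` returns only a limit of the assay, > 20000 nM. Compound 3 `CC(C)=CC[C@H]1C[C@]23C[C@@H](CC=C(C)C)C(C)(C)[C@H]4CCC(C)(C)O[C@]42OC(=O)C(C(=O)c2ccc(OC(=O)c4ccc(Br)cc4)c(OC(=O)c4ccc(Br)cc4)c2)=C3OC1(C)C` also returns only a limit, > 20000 nM. Compound 4 `CCC(=O)Oc1cc(C(=O)C2=C3OC(C)(C)[C@@H](CC=C(C)C)C[C@@]34C[C@@H](CC=C(C)C)C(C)(C)[C@H]3CCC(C)(C)O[C@]34OC2=O)ccc1O` has propanoyl in place of hydrogen on an oxygen on an aromatic ring of compound 2, so 3,4-dihydroxyphenyl becomes 4-hydroxy-3-(propanoyloxy)phenyl (propanoyl in place of hydrogen on an oxygen on an aromatic ring). Compound 2 at 7690 nM is the single anchor. The other two sit at the limit (the limit of > 20000 nM in this assay, at which 2 of the 3 values shown sit), so a modest move towards weaker inhibition is expected in this assay. The expected change is a 1.6-fold higher number from compound 2 to compound 4 (0.19 log units; within the scatter). For compound 4 the estimated value is 12000 nM, within an expected range of 6000 nM to 20000 nM.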

Compound 4, half-maximal inhibitory concentration: 12100 nM
For compound 4 the middle estimate is 1.0-fold (0.00 log units) below the measured one; the range from low to high includes it.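

Going from hydroxy to propanoyloxy in this assay gives a 1.6-fold higher number from compound 2 to compound 4 (0.20 log units; within the scatter), the first step in this set that can be read. At this oxygen on an aromatic ring, propanoyl can therefore take the place of hydrogen with no shift beyond the scatter. Compound 4 also gives a true number, not a limit of the assay: the limit of > 20000 nM in this assay, at which 2 of the 4 values shown sit.

Still open, going by these compounds, is whether a longer chain, such as hexanoyl, or an acyl group carrying an amine would be tolerated at this oxygen. On these data alone, the effect of propanoyl on the other hydroxy group also remains open.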